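Alkyne aryl variation on the shared core

This account rests on a few compounds, and the source may have more. Where it says the series, first, only, none or still open, it means among the compounds named here.

Measured so far in a functional assay on A375-C5 cells (Homo sapiens) for inhibition, read by sulforhodamine B assay, with a stated time of 48 h; on this read-out higher numbers stand for weaker inhibition of growth and lower numbers for stronger inhibition of growth:
compound 1 `COC(=O)c1sc2cc(C#Cc3ccccn3)cnc2c1N` gives 13900 nM
compound 2 `COC(=O)c1sc2cc(C#Cc3cccc(N)c3)cnc2c1N` gives 11600 nM
compound 3 `COC(=O)c1sc2cc(C#Cc3ccsc3)cnc2c1N` gives 29600 nM

Compound 1 stands second highest of the three numbers; its nearest neighbour is compound 2 with a 1.2-fold lower number from compound 1 to compound 2 (0.08 log units; within the scatter), its furthest compound 3 with a 2.1-fold higher number from compound 1 to compound 3 (0.33 log units; beyond the scatter). Compound 4 `COC(=O)c1sc2cc(C#Cc3ccc(F)cc3)cnc2c1N` is not yet measured. It differs from compound 1 as follows: 4-fluorophenyl in place of pyridin-2-yl on a triple-bonded carbon. Of the measured steps, a 1.2-fold lower number from compound 1 to compound 2 (0.08 log units; within the scatter) bears most directly, since it also puts a six-membered aromatic ring of carbon only in place of pyridin-2-yl and stayed within the scatter; a 2.6-fold higher number from compound 2 to compound 3 (0.41 log units; beyond the scatter) shows only a modest rise for the five-membered ring. No step beyond the scatter is therefore expected, and the step from compound 1 is estimated at a 1.2-fold lower number from compound 1 to compound 4 (0.06 log units; within the scatter). Compound 4 is expected to give about 12000 nM, with a range from 5500 nM to 26000 nM.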

Compound 4, concentration for 50% growth inhibition: 48400 nM
Compound 4: middle estimate off by 4.0-fold (0.61 log units), on the low side, outside the stated range (above it).
By their numbers in this assay, from the lowest: compounds 2 and 1 (each within the scatter of the next); then compounds 3 and 4 (each within the scatter of the next).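

In this assay the change to 4-fluorophenyl on the triple-bonded carbon gives a 3.5-fold higher number from compound 1 to compound 4 (0.54 log units; beyond the scatter) and a 4.2-fold higher number from compound 2 to compound 4 (0.62 log units; beyond the scatter) so a six-membered aromatic ring of carbon only does not by itself keep the number low at this position. Against thiophen-3-yl the same group shows a 1.6-fold higher number from compound 3 to compound 4 (0.21 log units; within the scatter) and the two stay unseparated. Plain phenyl and 4-aminophenyl on the triple-bonded carbon would show whether the fluorine, the amine or its place on the ring sets the gap between compound 2 and compound 4. No supporting data on hand account for that gap.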